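From sec-butyl to neopentyl on the aromatic nitrogen

The source may hold more compounds than are shown below. What is called first, only, known or untested is meant among the compounds shown, and "the series" means these compounds.

Compound 1 `COC(C)(C)CCn1nc(-c2cccs2)c(O)c(C2=NS(=O)(=O)c3cc(NS(C)(=O)=O)ccc3N2)c1=O` and compound 2 `CCC(C)n1nc(-c2cccs2)c(O)c(C2=NS(=O)(=O)c3cc(NS(C)(=O)=O)ccc3N2)c1=O` share one core and differ in the chain on an aromatic nitrogen. In an ADME assay on Huh-7 cells (Homo sapiens) for cytotoxicity, with a stated time of 72 h (on this read-out higher numbers stand for lower toxicity in this test and lower numbers for higher toxicity in this test), compound 1 gives > 33000 nM as a limit of the assay. Compound 2 gives > 33000 nM as a limit too, so it has no number of its own. For the measured compounds named here, the series so far rests on the limit of > 33000 nM in this assay, at which 2 of the 2 values shown sit, and on nothing finer.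

Compound 3 `CC(C)(C)Cn1nc(-c2cccs2)c(O)c(C2=NS(=O)(=O)c3cc(NS(C)(=O)=O)ccc3N2)c1=O` changes one group neopentyl in place of sec-butyl on an aromatic nitrogen with neopentyl in place of sec-butyl on an aromatic nitrogen. Since a step that the two limits leave unreadable from compound 1 to compound 2 has no size to carry over, no step beyond the scatter is expected in this assay for this change. The expected step is a step that the limit leaves unreadable from compound 2 to compound 3 on this estimate. For compound 3 the estimate is 35000 nM with an expected range from 15000 nM to 80000 nM and a report as a limit is the likely outcome.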

Compound 3, half-maximal cytotoxic concentration: > 1000 nM
Compound 3 ended at the assay's limit (the forecaster's own chance of this, stated with the estimate: 85%); the middle value lies beyond the limit too.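

For the compounds shown here, compound 1, compound 2 and compound 3 all stand as limits of the assay, so no step among them can be read. The compounds shown leave open where the half-maximal cytotoxic concentration of each lies and whether the chain on the aromatic nitrogen changes it at all.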